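This account rests on a few compounds, and the source may have more. Where it says the series, first, only, none or still open, it means among the compounds named here.

Measured so far:
compound 1, `CC(C)N1CCN(Cc2csc(N)c2C(=O)c2ccc(Cl)cc2)CC1`: 7.3%
compound 2, `Nc1scc(CN2CCN(c3ccccc3C(F)(F)F)CC2)c1C(=O)c1ccc(Cl)cc1`: -39%

In a functional assay on CHO cells with adenosine receptor A1 (Homo sapiens) as the target, read by cAMP accumulation and immunoassay, with a stated time of 6 min, tested at 1 uM (a higher number here means a weaker effect of the compound at the concentration tested, a lower number a stronger effect), compound 1 gives 7.3% and compound 2 gives -39%. Compound 2 stands lowest of the two numbers; its nearest neighbour is compound 1, and the step of a number 46.3 percentage points lower from compound 1 to compound 2 (beyond the scatter) separates them. Compound 3, `Nc1scc(CN2CCN(c3ccc(OC(F)(F)F)cc3)CC2)c1C(=O)c1ccc(Cl)cc1`, is not yet measured. It differs from compound 2 in one place: 4-(trifluoromethoxy)phenyl in place of 2-(trifluoromethyl)phenyl on an amine nitrogen in a ring. For the measured compounds named here, no measured step exchanges one aryl group for another on that ring nitrogen; the only measured step, a number 46.3 percentage points lower from compound 1 to compound 2 (beyond the scatter), trades an isopropyl for an aryl group and is a weak guide here. Since compound 2 and compound 3 both carry an aryl group there, the expected step is a number 14 percentage points higher from compound 2 to compound 3 (beyond the scatter), which may well stay within the scatter. Compound 3 is therefore estimated at -25% in this assay, between -55% and 10%.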

Compound 3, a percentage reported as activity, at one concentration (the size of the read-out at that concentration, not a potency): -51%
The estimate for compound 3 lay 26 percentage points above the measured number; the measured number falls inside the stated range.
By their numbers in this assay, from the lowest: compound 3; then compound 2; then compound 1.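

In this assay, exchanging one aryl group for another on the amine nitrogen in a ring still moves the read-out, with a number 12 percentage points lower from compound 2 to compound 3 (beyond the scatter). This modest step shows that the choice of aryl group matters, not just its presence. For the compounds shown here, the larger change remains the exchange of isopropyl for an aryl group, with a number 58.3 percentage points lower from compound 1 to compound 3 (beyond the scatter), so both aryl compounds now read lower than the only compound with an alkyl group at this position. No available evidence bears on why this exchange has this effect.

The step from 2-(trifluoromethyl)phenyl to 4-(trifluoromethoxy)phenyl changes both the substituent and its place on the phenyl ring, so the two contributions cannot be separated. The compounds shown also leave open how an unsubstituted phenyl or a pyridine ring would read on this nitrogen.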